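The source may report more compounds than this note shows. Statements on the series, on what has been measured and on what is new or still open speak of the compounds shown alone.

Going by the values given here, in a functional assay on DU-145 cells (Homo sapiens) for antiproliferative activity, read by propidium iodide staining, with a stated time of 96 h (a higher number here means a weaker inhibitor, a lower number a stronger inhibitor), compound 1 (`CC(O)(CSc1ccc(C(F)(F)F)cn1)C(=O)Nc1ccc(S(F)(F)(F)(F)F)cc1`) gives 30700 nM and compound 2 (`CC(O)(CS(=O)(=O)c1ccc(S(F)(F)(F)(F)F)cc1)C(=O)Nc1ccc(S(F)(F)(F)(F)F)cc1`) gives 28900 nM as the only two numbers so far. These two values lie within the scatter of each other, so compound 2 holds no separate standing on the numbers shown. Compound 3 (`CC(O)(CS(=O)(=O)c1ccc(C(F)(F)F)cc1)C(=O)Nc1ccc(S(F)(F)(F)(F)F)cc1`) departs from compound 2 by a single change (a group of 4 heavy atoms (1 carbon, 3 fluorine; no ring) in place of a group of 6 heavy atoms (5 fluorine, 1 sulfur; no ring), on an aromatic carbon): trifluoromethyl enters on an aromatic carbon, para to a large group, where the group of 6 heavy atoms stood. Among the compounds with values here, no measured pair shows this change, so the data give no direct size for it. Within the data shown here, with only two close values to go on, no step beyond the scatter is expected in either direction. The expected step of a 1.0-fold higher number from compound 2 to compound 3 (0.02 log units; within the scatter) in this assay is estimated to stay within the scatter. Compound 3 is expected at 30000 nM (estimated range 13000 nM to 65000 nM).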

Compound 3, half-maximal inhibitory concentration: 29300 nM
Compound 3: middle estimate off by 1.0-fold (0.01 log units), on the high side, and the stated range covers the measured number.
By their numbers in this assay, from the lowest: compounds 2, 3 and 1 (each within the scatter of the next).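

On the aromatic carbon para to a large group, trifluoromethyl in place of the group of 6 heavy atoms (5 fluorine, 1 sulfur) gives a 1.0-fold higher number from compound 2 to compound 3 (0.01 log units; within the scatter) in this assay. Going by these compounds alone, this is the first direct reading of any single change, and it separates the two groups by nothing beyond the scatter. At this position, in this assay, the two groups cannot be told apart, and no measurement at hand speaks to the reason for that.

As far as these compounds go, both groups compared here have 0 hydrogen-bond donors and 0 hydrogen-bond acceptors, so the response of this position to a different kind of group remains unknown. From the compounds shown here alone, whether an amine, a carboxylic acid or a plain hydrogen on this aromatic carbon would shift the number beyond the scatter stays open.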